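Swapping Pyrrolidine for Piperidine at the Side Chain's End

This account rests on a few compounds, and the source may have more. Where it says the series, first, only, none or still open, it means among the compounds named here.

Of the compounds shown here, two with a shared core have been tested so far in a functional assay on HCT-116 cells (Homo sapiens) for cytotoxicity, read by WST assay, with a stated time of 72 h; on this read-out lower numbers stand for stronger inhibition and higher numbers for weaker inhibition. Compound 1 `COc1cc2c(Nc3nc4ccc(C(=O)Nc5c(C)cc(C)cc5C)cc4s3)ncnc2cc1OCCCN1CCC(C)CC1` gives 6900 nM there. Compound 2 `COc1cc2c(Nc3nc4ccc(C(=O)Nc5c(C)cccc5C)cc4s3)ncnc2cc1OCCCN1CCCC1` gives > 100000 nM, and this figure is a limit of the assay, not a number. Any step that starts from compound 2 can therefore be sized only roughly.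

Compound 3 `COc1cc2c(Nc3nc4ccc(C(=O)Nc5c(C)cccc5C)cc4s3)ncnc2cc1OCCCN1CCCCC1` keeps all of compound 2 except the end of the side chain: piperidin-1-yl in place of pyrrolidin-1-yl on a saturated chain carbon, three bonds along the chain from an oxygen on an aromatic ring. Piperidin-1-yl stands in place of pyrrolidin-1-yl, on a saturated chain carbon, three bonds along the chain from an oxygen on an aromatic ring.

For the measured compounds named here, the only hint comes from compound 1, whose chain also ends in a six-membered non-aromatic ring and which gives 6900 nM, although it differs from compound 3 elsewhere too. A move toward stronger inhibition in this assay is thus expected, estimated as an at least 5.0-fold lower number from compound 2 to compound 3 (0.69 log units; beyond the scatter). For compound 3 the expected value is 20000 nM, with an estimated range from 5000 nM to 100000 nM.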

Compound 3, half-maximal inhibitory concentration: > 100000 nM
Compound 3: a limit, no number; the forecaster's own chance of this, stated with the estimate: 30%; at least 5.0-fold (0.69 log units) between middle value and limit.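

Compound 2 and compound 3 both give a limit of the assay rather than a number, so no step between them can be read: the limit of > 100000 nM in this assay, at which 2 of the 3 values shown sit.

The compounds shown leave open whether piperidin-1-yl in place of pyrrolidin-1-yl changes the strength of inhibition at all, and in which direction.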